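A few compounds are considered here, and "the series" means these few. Any claim that something is new, unique, unknown or untested is made for them only; others in the source may bear on it.

Measured so far:
- Compound 1 `Cn1c(=O)c2nc(-c3ccc(Cl)cc3)[nH]c2n(C)c1=O` — 0.8 nM
- Compound 2 `Cn1c(=O)c2nc(-c3ccc(Cl)cc3N)[nH]c2n(C)c1=O` — 0.35 nM

In an assay for binding affinity to adenosine receptor A1 (Bos taurus) (a higher number here means a weaker inhibitor, a lower number a stronger inhibitor), compound 1 gives 0.8 nM, the higher of the two numbers recorded; the nearest neighbour is compound 2, which gives 0.35 nM. Within the data shown here, the single measured step, a 2.3-fold lower number from compound 1 to compound 2 (0.36 log units; beyond the scatter), is a modest one and concerns an amino group entering elsewhere on the phenyl ring; it leaves the chloro in place.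

Compound 3 `CCCCOc1ccc(-c2nc3c(=O)n(C)c(=O)n(C)c3[nH]2)cc1` differs from compound 1 in one place: butoxy in place of chloro on an aromatic carbon. Among the measured compounds shown here, no measured step touches the chloro itself, so the amino step offers no direct guide to exchanging it for a butoxy chain, and the expected size of the move in this assay cannot be anchored to any recorded pair. The estimate therefore rests on compound 1 alone, with wide uncertainty, and a somewhat weaker number is expected: a 3.8-fold higher number from compound 1 to compound 3 (0.57 log units; beyond the scatter), giving for compound 3 an expected 3 nM within 0.6 nM to 15 nM.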

Compound 3, half-maximal inhibitory concentration: 4 nM
Beside the measured number, compound 3's estimate is 1.3-fold (0.12 log units) below it; measured number inside the range.
By their numbers in this assay, from the lowest: compound 2; then compound 1; then compound 3.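

Among these compounds, this is the first direct reading of the place para to a large group: in this assay, a 5.0-fold higher number from compound 1 to compound 3 (0.70 log units; beyond the scatter), a modest step. Replacing chloro with butoxy raises the heavy-atom count of the substituent from 1 to 5 and adds 1 hydrogen-bond acceptor, yet compound 3 still gives 4 nM, so this place accepts a much larger group with only a modest change in the number. Nothing available assigns a cause to this step.

Among the compounds shown here, the single pair leaves open whether the step follows the ether oxygen or the chain length, which methoxy, a butyl chain or a longer alkoxy chain at the same place could help separate. From the compounds shown here alone, a carboxylic acid or an amine there, and an amino group added to compound 3, also remain open.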